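A few compounds are considered here, and "the series" means these few. Any claim that something is new, unique, unknown or untested is made for them only; others in the source may bear on it.

Series notes. Compound 1 `Nc1cc(N)c2nc(-c3ccccc3)c(Sc3ccc(F)cc3)nc2c1` is the only member with a numeric reading: in a functional assay on SF-295 cells (Homo sapiens) for inhibition, read by sulforhodamine B assay, with a stated time of 48 h (a higher number here means that more compound is tolerated, a lower number that less compound is tolerated), compound 1 gives 64600 nM, and on the numbers shown it therefore stands alone, with nothing to rank it against. Compound 2 `CCOC(=O)[C@H](CCC(=O)O)NC(=O)c1ccc(CNc2nc3cc(N)cc(N)c3nc2-c2ccccc2)cc1` is the other measured member; in this assay compound 2 returns only a limit, < 100000 nM, which is the limit of < 100000 nM in this assay, at which 1 of the 2 values shown sits. For the measured compounds named here, no two measured compounds differ in a single place, so no measured step exists in this set. Compound 3 `Nc1cc(N)c2nc(-c3ccccc3)c(NCc3ccc(F)cc3)nc2c1` differs from compound 1 as follows: (4-fluorobenzyl)amino in place of (4-fluorophenyl)sulfanyl on an aromatic carbon. Going by the values given here, with nothing measured on this kind of change, the expectation is anchored to compound 1, whose 64600 nM is the one number available, and the step in this assay is expected to stay within the usual scatter, in no settled direction. Compound 3 is expected to give 55000 nM, within 15000 nM to 120000 nM. The expected step of a 1.2-fold lower number from compound 1 to compound 3 (0.07 log units; within the scatter) is accordingly small.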

Compound 3, concentration lethal to 50% of the cells: 64600 nM
The estimate for compound 3 lay 1.2-fold (0.07 log units) below the measured number; measured number inside the range.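

For the compounds shown here, the first readable step falls at this position, on the aromatic carbon next to the ring nitrogen and ortho to a phenyl group: in this assay, (4-fluorobenzyl)amino in place of (4-fluorophenyl)sulfanyl gives no change at the digits printed from compound 1 to compound 3 (within the scatter). The entering group carries a hydrogen-bond donor that the leaving group lacks, yet this exchange leaves the read-out unmoved at the digits printed. Compound 2 gives only a limit and adds no comparison: the limit of < 100000 nM in this assay, at which 1 of the 3 values shown sits.

A single step cannot separate the linking atom from the added carbon, so neither is shown to be without effect on its own. Also open, from the compounds shown here alone, is whether the reading holds with a plain amine, a carboxylic acid or a longer chain at this position, or with the fluorine removed from the benzyl ring.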